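A few compounds are considered here, and "the series" means these few. Any claim that something is new, unique, unknown or untested is made for them only; others in the source may bear on it.

The measured compounds in a functional assay on SW-620 cells (Homo sapiens) for cytotoxicity, read by colorimetric assay; on this read-out higher numbers stand for weaker inhibition and lower numbers for stronger inhibition:

compound 1 `O=C(/C=C/c1ccc(CN2C(=O)/C(=C3\Nc4ccccc4\C3=N/O)c3cc(Br)ccc32)cc1)NO`: 60 nM
compound 2 `O=C(NO)c1ccc(CN2C(=O)/C(=C3\Nc4ccccc4\C3=N/O)c3cc(F)ccc32)cc1`: 20 nM
compound 3 `O=C(/C=C/c1ccc(CN2C(=O)/C(=C3\Nc4ccccc4\C3=N/O)c3cc(F)ccc32)cc1)NO`: 50 nM

Compound 3 stands second highest of the three numbers. Its nearest neighbour is compound 1, separated by a 1.2-fold lower number from compound 1 to compound 3 (0.08 log units; within the scatter), a gap within the scatter. Within the data shown here, the only step here that lies beyond the scatter is a 2.5-fold higher number from compound 2 to compound 3 (0.40 log units; beyond the scatter), a modest one.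

Compound 4 `O=C(/C=C/c1ccc(CN2C(=O)/C(=C3\Nc4ccccc4\C3=N/O)c3ccccc32)cc1)NO` differs from compound 3 by hydrogen in place of fluoro on an aromatic carbon. Among the measured compounds shown here, only one measured step touches that aromatic carbon: a 1.2-fold lower number from compound 1 to compound 3 (0.08 log units; within the scatter), where one halogen took the place of another and the number stayed within the scatter. For the measured compounds named here, no measured step removes the halogen altogether, so the data give no direct precedent for a hydrogen at that place. Given that the one halogen exchange, a 1.2-fold lower number from compound 1 to compound 3 (0.08 log units; within the scatter), made no difference beyond the scatter, the step of a 1.1-fold higher number from compound 3 to compound 4 (0.04 log units; within the scatter) is expected to stay within the scatter, with no clear direction. Compound 4 is therefore estimated at 55 nM, with a range from 25 nM to 120 nM.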

Compound 4, half-maximal inhibitory concentration: 50 nM
Beside the measured number, compound 4's estimate is 1.1-fold (0.04 log units) above it; measured number inside the range.
By their numbers in this assay, from the lowest: compound 2; then compounds 3, 4 and 1 (each within the scatter of the next).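

Taking the halogen off altogether gives no change at the digits printed from compound 3 to compound 4 (within the scatter) when fluoro leaves and a 1.2-fold lower number from compound 1 to compound 4 (0.08 log units; within the scatter) when bromo leaves, both read in this assay. Across compounds 1, 3 and 4, all of which carry 2-(hydroxycarbamoyl)ethenyl, this aromatic carbon therefore takes bromo, fluoro or hydrogen with no step beyond the scatter, so a halogen there is not required to keep the number at this level. No measurement given here offers an explanation for this insensitivity.

On these data alone, it remains open whether a methoxy group, an amine or a carboxylic acid on that aromatic carbon would also stay within the scatter. It is equally open whether hydrogen would match fluoro in the hydroxycarbamoyl compound, where only compound 2, with fluoro, is shown.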